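The source may report more compounds than this note shows. Statements on the series, on what has been measured and on what is new or still open speak of the compounds shown alone.

Series notes, measured in a functional assay on U-251 cells (Homo sapiens) for antiproliferative activity, read by MTT assay, with a stated time of 48 h; on this read-out higher numbers stand for weaker inhibition and lower numbers for stronger inhibition:

- compound 1 `COc1cccc(-c2nc3cccc(-c4cc(OC)c(OC)c(OC)c4)c3o2)c1`: > 25000 nM (a limit of the assay, not a number)
- compound 2 `COc1cc(-c2cccc3nc(-c4cccc(Cl)c4)oc23)cc(OC)c1OC`: 18500 nM

Going by the values given here, compound 2 holds the only true number in this assay so far, 18500 nM, so there is no spread of numbers to rank it against.

Next is compound 3 `COc1cc(-c2cccc3nc(-c4ccc(C)cc4)oc23)cc(OC)c1OC`, not yet measured. The change is 4-methylphenyl in place of 3-chlorophenyl on an aromatic carbon.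

Among the compounds with values here, the one measured step, an at least 1.3-fold lower number from compound 1 to compound 2 (0.13 log units; that floor lies within the scatter), falls on the same phenyl group and stays within the scatter. It offers no ground for expecting a real shift in either direction, though a single step is thin support. The estimated change is a 1.1-fold higher number from compound 2 to compound 3 (0.03 log units; within the scatter), and no step beyond the scatter is expected. A result reported only as a limit would not surprise.

For compound 3 the expected value is 20000 nM, with an estimated range from 9000 nM to 40000 nM.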

Compound 3, half-maximal inhibitory concentration: 3200 nM
Compound 3: the middle estimate sits 6.3-fold (0.80 log units) above what was measured; the whole stated range lies above it.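

In this assay, the phenyl group on the aromatic carbon next to the ring nitrogen and next to the ring oxygen now shows a real effect: 4-methylphenyl in place of 3-chlorophenyl gives a 5.8-fold lower number from compound 2 to compound 3 (0.76 log units; beyond the scatter). 4-methylphenyl in place of 3-methoxyphenyl gives an at least 7.8-fold lower number from compound 1 to compound 3 (0.89 log units; beyond the scatter), whereas the earlier change at this position gave only an at least 1.3-fold lower number from compound 1 to compound 2 (0.13 log units; that floor lies within the scatter). Compound 1 stands only at a limit of the assay, so the size of its step to compound 3 is a floor: the limit of > 25000 nM in this assay, at which 1 of the 3 values shown sits.

Each step to compound 3 changes both the substituent and its place on the phenyl ring, and 3-methylphenyl and 4-chlorophenyl groups would separate the two. Also open, from the compounds shown here alone, is how this position responds to a 4-ethylphenyl or 4-aminophenyl group.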